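Swapping trifluoromethyl for cyano on the pyridine ether

This account rests on a few compounds, and the source may have more. Where it says the series, first, only, none or still open, it means among the compounds named here.

Of the compounds shown here, three sharing one core have been tested in an assay on brain for binding affinity to Neuronal acetylcholine receptor; alpha4/beta2 (Rattus norvegicus), read by radioligand binding; a lower number here means a stronger inhibitor, a higher number a weaker inhibitor. Compound 1 `Fc1cncc(OC[C@@H]2CCN2)c1` gives 0.076 nM, compound 2 `Clc1cncc(OC[C@@H]2CCN2)c1` gives 0.042 nM, and compound 3 `FC(F)(F)c1cncc(OC[C@@H]2CCN2)c1` gives 0.49 nM. Compound 3 stands highest of the three: the trifluoromethyl analogue sits a 6.4-fold higher number from compound 1 to compound 3 (0.81 log units; beyond the scatter) and a 12-fold higher number from compound 2 to compound 3 (1.07 log units; beyond the scatter), while the two halogen analogues lie close together, a 1.8-fold lower number from compound 1 to compound 2 (0.26 log units; within the scatter).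

Compound 4 `N#Cc1cncc(OC[C@@H]2CCN2)c1` differs from compound 3 at a single point: cyano in place of trifluoromethyl on an aromatic carbon. Going by the values given here, no measured step involves a cyano group, so the change has no direct precedent here. What the data do show is that replacing either halogen by trifluoromethyl pushed the number up by a modest to large amount, and that the two smaller substituents gave the lowest numbers. Moving from the four-atom trifluoromethyl back to a two-atom group is therefore expected to bring the number down, by a 4.1-fold lower number from compound 3 to compound 4 (0.61 log units; beyond the scatter), though the exact size is uncertain. Compound 4 is estimated at 0.12 nM, within a range of 0.03 nM to 0.5 nM.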

Compound 4, inhibition constant: 0.025 nM
The estimate for compound 4 lay 4.8-fold (0.68 log units) above the measured number; the measured number lies below the stated range.
By their numbers in this assay, from the lowest: compounds 4, 2 and 1 (each within the scatter of the next, the first and the last beyond it); then compound 3.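

Cyano at this position removes the rise seen with trifluoromethyl in this assay (a 20-fold lower number from compound 3 to compound 4 (1.29 log units; beyond the scatter)), the largest step among these four compounds. Low numbers here are therefore not confined to the two halogens: cyano cannot be told apart from chloro (a 1.7-fold lower number from compound 2 to compound 4 (0.23 log units; within the scatter)), yet it does separate from fluoro (a 3.0-fold lower number from compound 1 to compound 4 (0.48 log units; beyond the scatter)), even though chloro and fluoro themselves lie within the scatter of each other. Nothing measured here explains why cyano and trifluoromethyl differ so sharply at this position.

From the compounds shown here alone, whether the low numbers would hold for a methyl group, a methoxy group, an amine or a carboxylic acid at this position remains open. So does whether cyano would give a similar result at another position on the ring.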